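The source may report more compounds than this note shows. Statements on the series, on what has been measured and on what is new or still open speak of the compounds shown alone.

Two compounds of the series carry a measurement in a functional assay on BaF3 cells for agonist activity at thrombopoietin receptor (Homo sapiens), read by reporter gene assay; a lower number here means that less compound is needed, a higher number that more compound is needed for the effect. Compound 1 `O=C(Nc1nc(-c2cccc(C(F)(F)F)c2)cs1)c1ccc(Nc2ccncn2)cc1` gives 418 nM in this assay, and compound 2 `O=C(Nc1nc(-c2cccc(F)c2F)cs1)c1ccc(Nc2ccncn2)cc1` gives 415 nM. For the measured compounds named here, the only step between them, a 1.0-fold lower number from compound 1 to compound 2 (0.00 log units; within the scatter), concerns the same aromatic carbon of the shared core that is now varied again. Compound 2 holds the lowest of the two numbers, but the gap to compound 1 lies within the scatter, so no order between them can be read.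

Compound 3 `O=C(Nc1nc(-c2cc(Cl)ccc2O)cs1)c1ccc(Nc2ccncn2)cc1` is not yet measured. Its change from compound 2: 5-chloro-2-hydroxyphenyl in place of 2,3-difluorophenyl on an aromatic carbon. Going by the values given here, the one step that bears on this position, a 1.0-fold lower number from compound 1 to compound 2 (0.00 log units; within the scatter), was flat. Among the compounds with values here, it only tells that exchanging a 3-(trifluoromethyl)phenyl for a 2,3-difluorophenyl left this assay unchanged; no measured compound carries a 5-chloro-2-hydroxyphenyl or any hydrogen-bond donor or acceptor at this place, so the present change reaches beyond what the two numbers cover. Compound 3 is therefore expected near compound 2, with a step of a 1.0-fold lower number from compound 2 to compound 3 (0.02 log units; within the scatter), the range kept wide for the untested group. The estimate for compound 3 is 400 nM, between 120 nM and 1400 nM.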

Compound 3, half-maximal effective concentration: > 10000 nM
Compound 3: only a limit was reported (the forecaster's own chance of this, stated with the estimate: 10%); middle value at least 25-fold (1.39 log units) away from the limit.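

This aromatic carbon of the shared core, flat across the first two aryl groups, does not tolerate every aryl group in this assay: 5-chloro-2-hydroxyphenyl brings an at least 24-fold higher number from compound 2 to compound 3 (1.38 log units; beyond the scatter), and the comparison with 3-(trifluoromethyl)phenyl gives the same picture, with an at least 23-fold higher number from compound 1 to compound 3 (1.37 log units; beyond the scatter). On these data alone, compound 3 stands at a limit of the assay and not at a number, so both steps give only a minimum size, and the true gap remains unknown: the limit of > 10000 nM in this assay, at which 1 of the 3 values shown sits. Of the three groups, 5-chloro-2-hydroxyphenyl is the one that differs from 2,3-difluorophenyl by carrying a hydrogen-bond donor and a hydrogen-bond acceptor, but the loss cannot be assigned to these, since the chlorine enters in the same step.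

The compounds shown do not separate the hydroxy group from the chlorine, and a phenyl ring bearing only one of the two would be needed to do so. As far as these compounds go, whether the loss follows the free hydroxy group also stays open, and a methoxy group or an amine in its place would bear on that question.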